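Swapping Tert-Butyl for Pentan-3-yl on a Weak Compound

The source may report more compounds than this note shows. Statements on the series, on what has been measured and on what is new or still open speak of the compounds shown alone.

The measurements come from a functional assay on the whole organism (blood, strain Wistar-Okamoto) with Rattus norvegicus as the target, with a stated time of 5 days (on this read-out higher numbers stand for an effect only at larger amounts of compound and lower numbers for an effect already at smaller amounts), in which rats receive the compounds. Compound 1 `CC(C)/N=C(\NC#N)Nc1cccnc1` gives 2.5 mg/kg in this assay. Compound 2 `CCC(C)(C)N/C(=N\C#N)Nc1ccc[n+]([O-])c1`, built on a different core and dosed the same way, gives 20 mg/kg in this assay, a higher number than compound 1 shows. Compound 3 `CC(C)(C)N/C(=N\O)Nc1cccnc1` is the starting point here, and in this assay compound 3 gives only > 35 mg/kg, which is a limit of the assay rather than a measured number. Compound 3 thus sits at the limit of > 35 mg/kg in this assay, at which 1 of the 3 values shown sits, with no value beneath it to work from.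

Compound 4 `CCC(CC)N/C(=N\O)Nc1cccnc1` differs from compound 3 in a single place: pentan-3-yl in place of tert-butyl on an amine nitrogen. Both groups are short branched alkyl chains without rings or charge, and the change adds one carbon.

For the measured compounds named here, no measured step between two compounds is available to gauge this change. Because compound 3 gives only > 35 mg/kg, the step from compound 3 to compound 4 is expected to be small or none beyond the scatter, a step that the limit leaves unreadable from compound 3 to compound 4. Compound 4 is therefore expected to give about 40 mg/kg in this assay, most likely again as a limit, within a range from 20 mg/kg to 100 mg/kg.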

Compound 4, minimum effective dose: 50 mg/kg
Compound 4: middle estimate off by 1.3-fold (0.10 log units), on the low side; the range from low to high includes it.
By their numbers in this assay, from the lowest: compound 1; then compound 2; then compound 4.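

No step can be read between compound 3 and compound 4, because compound 3 carries only a limit and not a number: the limit of > 35 mg/kg in this assay, at which 1 of the 4 values shown sits.

The compounds shown leave open whether pentan-3-yl in place of tert-butyl on an amine nitrogen shifts the dose needed for an effect at all, in either direction.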